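Enlarging the small ring on a short-lived compound

A few compounds are considered here, and "the series" means these few. Any claim that something is new, unique, unknown or untested is made for them only; others in the source may bear on it.

Compound 1 `C1CCC(C(CC2CCCCN2)C2CC2)CC1` gives 0.05 h as its half-life
Compound 2 `C1CCC(C(CC2CCCCN2)C2CCC2)CC1` gives 0.167 h as its half-life

For the measured compounds named here, these half-lives come from an ADME assay on microsomes from liver (Rattus norvegicus, strain Sprague-Dawley) for metabolic stability, read by LC-MS, using NADPH, with a stated time of 45 min, tested at 3 uM (on this read-out higher numbers stand for a longer-lived compound and lower numbers for a shorter-lived compound), and are the only measurements so far. Compound 1 stands lowest of the two numbers, with compound 2 as its nearest neighbour. Going by the values given here, the unmeasured compound 3 `C1CCC(C(CC2CCCCN2)C2CCCC2)CC1` keeps the core of compound 1, and cyclopentyl in place of cyclopropyl on a saturated chain carbon bound to a saturated chain carbon and a saturated ring carbon is the only change. Among the compounds with values here, the one measured step that bears on it is a 3.3-fold higher number from compound 1 to compound 2 (0.52 log units; beyond the scatter) and it is modest, yet beyond the usual scatter. That step put cyclobutyl in place of cyclopropyl at the same place. Cyclopentyl is a larger ring still, so a rise of similar or somewhat larger size seems likely, although a single step cannot establish a trend. The expected step is a 4.0-fold higher number from compound 1 to compound 3 (0.60 log units; beyond the scatter) in the upward direction. For compound 3 the estimated half-life is 0.2 h with an expected range from 0.08 h to 0.5 h for repeated measurements.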

Compound 3, half-life: 0.317 h
Compound 3: the middle estimate sits 1.6-fold (0.20 log units) below what was measured, within the range that was stated.
By their numbers in this assay, from the lowest: compound 1; then compounds 2 and 3 (each within the scatter of the next).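

Putting cyclopentyl in place of cyclopropyl on this saturated chain carbon gives, in this assay, a 6.3-fold higher number from compound 1 to compound 3 (0.80 log units; beyond the scatter), so a second, larger ring also stands clearly apart from cyclopropyl. The direct comparison of the two larger rings is a 1.9-fold higher number from compound 2 to compound 3 (0.28 log units; within the scatter), so compound 2 and compound 3 cannot be told apart, and a steady gain with each added ring carbon is not shown. No experiment or other information given here says what lies behind these differences.

Still open, going by these compounds, is whether a cyclohexyl ring or an open isopropyl group at this place would give a half-life like that of compound 3. On these data alone, it is also open whether a tetrahydropyranyl ring, which carries an oxygen atom, would behave like these all-carbon rings.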